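Oxime ether series: cyano for methyl on the pendant aryl

The source may hold more compounds than are shown below. What is called first, only, known or untested is meant among the compounds shown, and "the series" means these compounds.

Measured so far:
compound 1 `Cc1ccc(-c2nc3sccn3c2/C=N/OCc2ccc(Cl)c(Cl)c2)cc1` — 490 nM
compound 2 `Fc1c(F)c(F)c(CO/N=C/c2c(-c3ccc4ccccc4c3)nc3occn23)c(F)c1F` — 1700 nM
compound 3 `Clc1ccc(CO/N=C/c2c(-c3ccc4ccccc4c3)nc3occn23)cc1` — 990 nM

In an assay on HepG2 cells for agonist activity at nuclear receptor subfamily 1 group I member 3 (Homo sapiens), read by a luciferase reporter, with a stated time of 23 h (on this read-out lower numbers stand for an effect already at smaller amounts and higher numbers for an effect only at larger amounts of compound), compound 1 gives the lowest number of the three; compound 3 is the nearest and stands higher by a gap beyond the scatter, and compound 2 stands higher still, also beyond the scatter. Among the compounds with values here, the only step between two measured compounds that differ in one place is a 1.7-fold lower number from compound 2 to compound 3 (0.23 log units; within the scatter). That step changes the group on the saturated chain carbon bound to the oxygen, not the ring carried directly on the shared core, and it stays within the scatter.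

Compound 4 `N#Cc1ccc(-c2nc3sccn3c2/C=N/OCc2ccc(Cl)c(Cl)c2)cc1` has not been measured. It differs from compound 1 by cyano in place of methyl on an aromatic carbon. Within the data shown here, no measured pair in this set changes anything on the ring carried on the shared core, so the data give no direct guide for this change. In the absence of such a guide, the step from compound 1 to compound 4 is expected to be a 1.2-fold higher number from compound 1 to compound 4 (0.09 log units; within the scatter), that is, not beyond the scatter in either direction. Compound 4 is therefore estimated at 600 nM, with a range from 220 nM to 1700 nM.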

Compound 4, half-maximal effective concentration: 3400 nM
The estimate for compound 4 lay 5.7-fold (0.75 log units) below the measured number; the whole stated range lies below it.
By their numbers in this assay, from the lowest: compound 1; then compounds 3, 2 and 4 (each within the scatter of the next, the first and the last beyond it).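

In this assay, the change from 4-methylphenyl to 4-cyanophenyl gives a 6.9-fold higher number from compound 1 to compound 4 (0.84 log units; beyond the scatter), the first read on the ring carried directly on the shared core. Within the data shown here, the only earlier step, a 1.7-fold lower number from compound 2 to compound 3 (0.23 log units; within the scatter), changed the group on the saturated chain carbon bound to the oxygen and stayed within the scatter, so it said nothing about this ring. The place para to a large group on the six-membered aromatic ring is therefore not indifferent to what it carries: cyano in place of methyl, with one more heavy atom, a triple bond and one hydrogen-bond acceptor, moves the number up beyond the scatter, and no measurement at hand bears on the reason for this.

From the compounds shown here alone, with only methyl and cyano at this place, it remains open whether the higher number is particular to cyano or would also appear with other groups, such as an amine, a carboxylic acid or a longer chain. Also open, going by these compounds, is whether the same change would give a step of similar size on compound 3 or compound 2, which carry a different ring on a different core.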